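Replacing the aryl piperazine substituent with a small amide

This account rests on a few compounds, and the source may have more. Where it says the series, first, only, none or still open, it means among the compounds named here.

Three compounds share a core in which a benzyl ether is linked through an aromatic ring and an isoxazole to a piperazine. Compound 1 `Cc1cccc(COc2ccc(-c3cc(CN4CCN(Cc5ccc(C(F)(F)F)cc5)CC4)no3)cc2)c1` gives 5000 nM in a functional assay on Huh-7 cells (Homo sapiens) for antiproliferative activity, read by sulforhodamine B assay, with a stated time of 72 h; on this read-out lower numbers stand for stronger inhibition and higher numbers for weaker inhibition. Going by the values given here, compound 2 `Fc1ccccc1COc1ccc(-c2cc(CN3CCN(Cc4ccc(C(F)(F)F)cc4)CC3)no2)cc1` gives 1500 nM in this assay, and the change a 3.3-fold lower number from compound 1 to compound 2 (0.52 log units; beyond the scatter) is the only single-point step among the measured compounds. Compound 3 `N#Cc1cccc(COc2ccc(-c3cc(CN4CCN(c5ccc(C(F)(F)F)cn5)CC4)no3)cc2)c1` gives 1700 nM in this assay; it stands second highest of the three numbers, within the scatter of compound 2 and beyond the scatter below compound 1.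

Compound 4 `N#Cc1cccc(COc2ccc(-c3cc(CN4CCN(C(=O)C5CCCO5)CC4)no3)cc2)c1` has not yet been measured. It differs from compound 3 by (oxolan-2-yl)carbonyl in place of 5-(trifluoromethyl)pyridin-2-yl on an amine nitrogen in a ring. Among the compounds with values here, none of the measured steps touches this position: the one step that exists concerns the benzyl ether end, and compounds 1, 2 and 3 all carry a trifluoromethyl-bearing aromatic group on the piperazine nitrogen. Within the data shown here, there is therefore no direct precedent for the size or direction of the step in this assay, and the estimate rests on the broad spread of the three numbers. Compound 4 is expected to move by a 2.9-fold higher number from compound 3 to compound 4 (0.47 log units; beyond the scatter), toward a weaker result, with wide uncertainty. Compound 4 is estimated at 5000 nM, within the range 1500 nM to 20000 nM.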

Compound 4, half-maximal inhibitory concentration: 2200 nM
Compound 4: the middle estimate sits 2.3-fold (0.36 log units) above what was measured; low and high end bracket the measured number.
By their numbers in this assay, from the lowest: compounds 2, 3 and 4 (each within the scatter of the next); then compound 1.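

In this assay, going by these compounds alone, putting (oxolan-2-yl)carbonyl in place of 5-(trifluoromethyl)pyridin-2-yl on the amine nitrogen gives a 1.3-fold higher number from compound 3 to compound 4 (0.11 log units; within the scatter), the first reading at this position. Until now, every compound had carried a trifluoromethyl-bearing aromatic group on this nitrogen, and this pair shows that, with the rest of compound 3 unchanged, a non-aromatic five-membered ring attached through a carbonyl gives a number indistinguishable from that of the aromatic group, although it brings fewer heavy atoms and no trifluoromethyl. No measurement is available that explains why this exchange leaves the number within the scatter.

The compounds shown leave open whether the same exchange would hold with the 2-fluorophenyl or 3-methylphenyl group at the benzyl ether end, since this single pair carries the nitrile-bearing one. They also leave open how far this nitrogen can be varied, for instance with a plain acetyl group, a longer chain ending in an amine or a carboxylic acid, or the open-chain counterpart of the oxolane ring.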